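The compounds below may be only part of what the source reports. "The series", "measured", "known", "first", "only" and "open" are said of these compounds alone.

Working notes on the series, read in an ADME assay on the whole organism (serum) with Homo sapiens as the target; on this read-out higher numbers stand for a longer-lived compound and lower numbers for a shorter-lived compound. Compound 1 `Cc1cn(C2CC(N=[N+]=[N-])C(COC(=O)NCCCC(=O)O)O2)c(=O)[nH]c1=O` gives > 48 h, which is a limit of the assay and not a number. Going by the values given here, compound 2 `Cc1cn(C2CC(N=[N+]=[N-])C(COC(=O)CCCC(=O)O)O2)c(=O)[nH]c1=O` gives 30 h, the only exact number so far. Compound 3 `Cc1cn(C2CC(N=[N+]=[N-])C(COC(=O)OCCCN)O2)c(=O)[nH]c1=O` carries 3-aminopropoxy in place of 3-carboxypropyl on a carbonyl carbon. Among the compounds with values here, one measured step bears on this, also a change on a carbonyl carbon: an at least 1.6-fold lower number from compound 1 to compound 2 (0.20 log units; that floor lies within the scatter). Within the data shown here, it gives only a floor on its size, and no measured compound carries 3-aminopropoxy, so the guide is weak. In this assay a modest downward move is expected, with no firm case for a change beyond the scatter. The expected step is a 1.7-fold lower number from compound 2 to compound 3 (0.22 log units; within the scatter). For compound 3 the estimated half-life is 18 h, with an expected range of 5 h to 45 h.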

Compound 3, half-life: 0.133 h
For compound 3 the middle estimate is 140-fold (2.13 log units) above the measured one; measured number below the stated range.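

In this assay the read-out proves highly sensitive to the group on this carbonyl carbon, which the earlier floor, lying within the scatter, gave no sign of: 3-aminopropoxy in place of 3-carboxypropyl gives a 230-fold lower number from compound 2 to compound 3 (2.35 log units; beyond the scatter). Set against the (3-carboxypropyl)amino group, 3-aminopropoxy gives an at least 360-fold lower number from compound 1 to compound 3 (2.55 log units; beyond the scatter). Compound 1 stands at a limit of the assay and not at a number, so this step is only a floor: the limit of > 48 h in this assay, at which 1 of the 3 values shown sits.

Which part of the change goes with the drop stays open, since 3-aminopropoxy differs from both other groups in its end group and from 3-carboxypropyl in its link to the carbonyl carbon. A 3-carboxypropoxy group, keeping the carboxylic acid on an oxygen link, or a (3-aminopropyl)amino group, keeping the amine on a nitrogen link, would separate the two.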